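The source may hold more compounds than are shown below. What is called first, only, known or untested is meant among the compounds shown, and "the series" means these compounds.

In a functional assay on HeLa cells (Homo sapiens) for cytotoxicity, read by CCK-8 assay (on this read-out higher numbers stand for weaker inhibition and lower numbers for stronger inhibition), compound 1 `O=C(Nc1ccc(O)cc1)c1ncc(-c2ccccc2)o1` gives 780 nM as its value. Compound 2 `COc1ccc(NC(=O)c2ncc(-c3ccccc3)o2)cc1` gives > 30000 nM there, which is a limit of the assay and not a number. Compound 3 `COc1ccc(NC(=O)c2ncc(-c3ccc(O)cc3)o2)cc1` carries hydroxy in place of hydrogen on an aromatic carbon as its change, hydroxy in place of hydrogen on an aromatic carbon, para to a large group. Within the data shown here, the only measured guide is an at least 38-fold higher number from compound 1 to compound 2 (1.58 log units; beyond the scatter) for methyl in place of hydrogen on an oxygen on an aromatic ring, a large step at a different place, so a moderate fall in the number is expected and the limit remains possible. For compound 3 the estimated value is 6000 nM within an expected range of 1000 nM to 30000 nM in this assay. The expected change is an at least 5.0-fold lower number from compound 2 to compound 3 (0.69 log units; beyond the scatter) on that estimate.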

Compound 3, half-maximal inhibitory concentration: 9670 nM
Compound 3: the middle estimate sits 1.6-fold (0.21 log units) below what was measured, and the stated range covers the measured number.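

Phenyl to 4-hydroxyphenyl shows that a second place in the series responds in this assay, since hydroxy in place of hydrogen on this aromatic carbon gives an at least 3.1-fold lower number from compound 2 to compound 3 (0.49 log units; beyond the scatter) and brings the value off the limit. On these data alone, the true size of this step is unknown because compound 2 stands at a limit and not at a number: the limit of > 30000 nM in this assay, at which 1 of the 3 values shown sits.

As far as these compounds go, it stays open whether this hydroxy has the same effect when the free hydroxy of compound 1 is present on the other ring. Also open, from the compounds shown here alone, is how an amine or a carboxylic acid at this position would compare with hydroxy.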